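Swapping furan-2-yl for 4-hydroxyphenyl in a cytotoxic series

The source may hold more compounds than are shown below. What is called first, only, known or untested is meant among the compounds shown, and "the series" means these compounds.

Measured in a functional assay on HeLa cells (Homo sapiens) for cytotoxicity, read by ELISA, with a stated time of 2 days; a higher number here means a weaker inhibitor, a lower number a stronger inhibitor:
Compound 1 `Oc1ccc(-c2cc(-c3ccccc3)cc(-c3ccccc3)n2)cc1`: 1700 nM
Compound 2 `Oc1ccc(-c2cc(-c3ccccc3)cc(-c3cccs3)n2)cc1`: 1700 nM
Compound 3 `Oc1ccc(-c2cc(-c3ccccc3)cc(-c3ccco3)n2)cc1`: 10900 nM

Among these three, compound 3 stands at the weak end with 10900 nM, the highest number shown. Compound 4 `Oc1ccc(-c2cc(-c3ccccc3)cc(-c3ccc(O)cc3)n2)cc1` has not yet been measured. It carries 4-hydroxyphenyl in place of furan-2-yl on an aromatic carbon, (4-hydroxyphenyl in place of furan-2-yl on an aromatic carbon). The closest evidence is the step of a 6.4-fold higher number from compound 1 to compound 3 (0.81 log units; beyond the scatter), which introduced furan-2-yl in place of phenyl. The step of a 6.4-fold higher number from compound 2 to compound 3 (0.81 log units; beyond the scatter) has the same size, while the step of no change at the digits printed from compound 1 to compound 2 (within the scatter) shows no separation between phenyl and thiophen-2-yl. Leaving furan-2-yl might therefore recover much of that modest loss. Among the measured compounds shown here, no measured step shows what the hydroxy group on the phenyl does, so the recovery is uncertain and could be partial. In this assay a modest move to a lower number is expected, an estimated 3.9-fold lower number from compound 3 to compound 4 (0.59 log units; beyond the scatter). For compound 4 the estimated value is 2800 nM, with an expected range from 800 nM to 9000 nM.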

Compound 4, half-maximal inhibitory concentration: 3300 nM
Beside the measured number, compound 4's estimate is 1.2-fold (0.07 log units) below it; low and high end bracket the measured number.
By their numbers in this assay, from the lowest: compounds 1, 2 and 4 (each within the scatter of the next); then compound 3.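

Placing 4-hydroxyphenyl at this position, on an aromatic carbon next to the ring nitrogen, gives a 3.3-fold lower number from compound 3 to compound 4 (0.52 log units; beyond the scatter) in this assay, so the furan-2-yl loss does not carry over to this group. Among the compounds shown here, the hydroxy group, which no earlier step covered, shows a 1.9-fold higher number from compound 1 to compound 4 (0.29 log units; within the scatter), and the comparison with thiophen-2-yl shows a 1.9-fold higher number from compound 2 to compound 4 (0.29 log units; within the scatter), so phenyl, thiophen-2-yl and 4-hydroxyphenyl are not separated here, while furan-2-yl alone stands apart. Nothing measured in these compounds explains why furan-2-yl differs from the other three groups.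

On these data alone, whether an amine or a carboxylic acid in place of the hydroxy group would stay level with these compounds remains open. So does whether a saturated ring such as piperidine would be accepted at this position.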